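The source may hold more compounds than are shown below. What is called first, only, known or untested is meant among the compounds shown, and "the series" means these compounds.

Of the compounds shown here, three share one core and have been tested in a functional assay on CHO cells for antagonist activity at Gonadotropin-releasing hormone receptor (Homo sapiens), read by a luciferase reporter, with a stated time of 30 min; on this read-out lower numbers stand for stronger inhibition and higher numbers for weaker inhibition. Compound 1, `CCNC(=O)Nc1ccc(-c2nc3n(Cc4c(F)cccc4F)cc(C(=O)OCC)c(=O)n3c2CN(CC(=O)NCc2cn(CCN=[N+]=[N-])nn2)Cc2ccccc2)cc1`, carries an azido group on a short chain attached to its triazole; in this assay compound 1 gives 724 nM. Compound 2, `CCNC(=O)Nc1ccc(-c2nc3n(Cc4c(F)cccc4F)cc(C(=O)OCC)c(=O)n3c2CN(CC(=O)NCc2cn(CCOCCOCCOCCOCCN=[N+]=[N-])nn2)Cc2ccccc2)cc1`, carries the same azide at the end of a longer chain of repeating ether links, and compound 2 gives 832 nM. Compound 3, `C#CCNC(=O)Nc1ccc(-c2nc3n(Cc4c(F)cccc4F)cc(C(=O)OCC)c(=O)n3c2CN(C)Cc2ccccc2)cc1`, has a simpler side chain and a propargyl urea in place of the ethyl urea, and compound 3 gives 676 nM. Among these three numbers compound 1 stands second highest, with compound 3 at a slightly lower number and compound 2 at a slightly higher one; both gaps lie within the scatter of repeated measurements, so the three cannot be ranked.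

Compound 4, `CCNC(=O)Nc1ccc(-c2nc3n(Cc4c(F)cccc4F)cc(C(=O)OCC)c(=O)n3c2CN(CC(=O)NCc2cn(CCOCCOCCOCCN=[N+]=[N-])nn2)Cc2ccccc2)cc1`, is the next compound to be measured. It differs from compound 1 in one place: 2-(2-(2-azidoethoxy)ethoxy)ethoxy in place of azido on a saturated chain carbon, two bonds along the chain from an aromatic nitrogen. The new chain is intermediate in length between those of compound 1 and compound 2, and those two compounds differ by less than the scatter. No step beyond the scatter is therefore expected, and a 1.1-fold higher number from compound 1 to compound 4 (0.03 log units; within the scatter) is estimated to stay within it. Compound 4 is expected to give about 770 nM, in a range from 400 nM to 1500 nM.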

Compound 4, half-maximal inhibitory concentration: 724 nM
The estimate for compound 4 lay 1.1-fold (0.03 log units) above the measured number; measured number inside the range.
By their numbers in this assay, from the lowest: compounds 3, 1, 4 and 2 (each within the scatter of the next).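

In this assay there is no change at the digits printed from compound 1 to compound 4 (within the scatter) when 2-(2-(2-azidoethoxy)ethoxy)ethoxy takes the place of azido on a saturated chain carbon, two bonds along the chain from an aromatic nitrogen. Within the data shown here, this is the first step that can be read at this position, and it shows that the position accepts a much larger group with no measurable change: the entering group has 12 heavy atoms and 4 hydrogen-bond acceptors, while azido has 3 heavy atoms and 1 hydrogen-bond acceptor. Nothing measured alongside these compounds explains why the number stays the same.

All the chains shown here end in the same azido group, so the effect of a different end group, such as an amine or a carboxylic acid, remains open. Among these compounds, also open is how a chain longer than the one in compound 2 would behave at this position, and whether the number would eventually move beyond the usual scatter of repeated measurements.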